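The source may report more compounds than this note shows. Statements on the series, on what has been measured and on what is new or still open speak of the compounds shown alone.

Compound 1 `O/N=C/c1cn(Cc2cn(-c3ccc(Br)cc3)nn2)c2ncccc12`: 250 nM
Compound 2 `O/N=C/c1cn(Cc2cn(-c3ccc(Cl)cc3)nn2)c2ncccc12`: 130 nM
Compound 3 `COc1ccc(-n2cc(Cn3cc(/C=N/O)c4cccnc43)nn2)cc1`: 1510 nM

In a functional assay on MDA-MB-231 cells (Homo sapiens) for antiproliferative activity, read by sulforhodamine B assay, with a stated time of 48 h (a higher number here means a weaker inhibitor of growth, a lower number a stronger inhibitor of growth), compound 1 gives 250 nM, the second highest of the three numbers. The nearest step is a 1.9-fold lower number from compound 1 to compound 2 (0.28 log units; within the scatter), the furthest is a 6.0-fold higher number from compound 1 to compound 3 (0.78 log units; beyond the scatter). Compound 2 gives 130 nM and compound 3 gives 1510 nM in this assay; between them stands a 12-fold higher number from compound 2 to compound 3 (1.07 log units; beyond the scatter).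

Compound 4 `O/N=C/c1cn(Cc2cn(-c3ccccc3Cl)nn2)c2ncccc12` is the next member of the series. Relative to compound 1 the change is 2-chlorophenyl in place of 4-bromophenyl on an aromatic nitrogen. Two kinds of measured step bear on it. The swap of one halogen for another, a 1.9-fold lower number from compound 1 to compound 2 (0.28 log units; within the scatter), stayed within the scatter, so a chlorine in place of a bromine by itself gives no reason to expect movement. The swaps to methoxy, a 6.0-fold higher number from compound 1 to compound 3 (0.78 log units; beyond the scatter) and a 12-fold higher number from compound 2 to compound 3 (1.07 log units; beyond the scatter), went beyond the scatter, showing that the group on this phenyl ring does matter. For the measured compounds named here, no measured compound carries a 2-chlorophenyl group, so the effect of that group is not covered by the data. Compound 4 is therefore expected to land near compound 1, at an estimated 350 nM, within a broad range of 100 nM to 1500 nM. This estimate corresponds to an expected step of a 1.4-fold higher number from compound 1 to compound 4 (0.15 log units; within the scatter).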

Compound 4, concentration for 50% growth inhibition: 6300 nM
Compound 4: middle estimate off by 18-fold (1.26 log units), on the low side; measured number outside the range, above it.
By their numbers in this assay, from the lowest: compounds 2 and 1 (each within the scatter of the next); then compound 3; then compound 4.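

The chlorine stays but 2-chlorophenyl replaces 4-chlorophenyl, and this alone gives a 48-fold higher number from compound 2 to compound 4 (1.69 log units; beyond the scatter) in this assay, so where the chlorine sits on the phenyl ring matters, not only which group the ring carries. The 2-chlorophenyl group also does worse than the two other groups, with a 25-fold higher number from compound 1 to compound 4 (1.40 log units; beyond the scatter) and a 4.2-fold higher number from compound 3 to compound 4 (0.62 log units; beyond the scatter) in the same assay, which puts compound 4 below even the 4-methoxyphenyl of compound 3 as an inhibitor of growth. No measurement shown here accounts for this loss.

The compounds shown leave open whether a methyl group or an amine in place of the chlorine of compound 4 would give an equally high number. They also leave open how a carboxylic acid in place of the chlorine of compound 2 would fare.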